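Thiazolyl for Methyl on the Amine: Cytotoxicity Outlook

The source may report more compounds than this note shows. Statements on the series, on what has been measured and on what is new or still open speak of the compounds shown alone.

Measured so far:
Compound 1 `Nc1nc(Cl)c(-c2ccccn2)c(N[C@@H]2C[C@H](CO)[C@@H](O)[C@H]2O)n1`: in an ADME assay on cells (Homo sapiens) for cytotoxicity, read by polymerase chain reaction, with a stated time of 3 days (on this read-out lower numbers stand for higher toxicity in this test and higher numbers for lower toxicity in this test), compound 1 gives > 25000 nM, which is a limit of the assay rather than a number.
Compound 2 `COc1ccc2nc(-c3c(Cl)nc(N)nc3N[C@@H]3C[C@H](CO)[C@@H](O)[C@H]3O)sc2c1`: in this assay compound 2 gives > 25000 nM, again a limit.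
Compound 3 `CNc1nc(C)c(-c2nc3ccccc3s2)c(N[C@@H]2C[C@H](CO)[C@@H](O)[C@H]2O)n1`: in this assay compound 3 gives > 25000 nM, also a limit.

Going by the values given here, compound 3 therefore stands where every measured compound stands, at the limit of > 25000 nM in this assay, at which 3 of the 3 values shown sit; no compound shows a measurable toxicity, and no step between two numbers exists.

Compound 4 `Cc1nc(Nc2nccs2)nc(N[C@@H]2C[C@H](CO)[C@@H](O)[C@H]2O)c1-c1nc2ccccc2s1` differs from compound 3 by 1,3-thiazol-2-yl in place of methyl on a nitrogen on an aromatic ring.

Because compound 3 sits at the limit of > 25000 nM in this assay, at which 3 of the 3 values shown sit, together with the other two compounds, I expect no step beyond the scatter, a step that the limit leaves unreadable from compound 3 to compound 4, and most likely another limit. Compound 4 is estimated at 30000 nM, within 10000 nM to 100000 nM.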

Compound 4, half-maximal cytotoxic concentration: 15000 nM
Estimate against measurement, compound 4: 2.0-fold (0.30 log units) above; measured number inside the range.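

In this assay, going by these compounds alone, compound 4 gives 15000 nM, the first real number in this set rather than a limit, so a change on this nitrogen can bring a reading into the measurable range. The swap of methyl for 1,3-thiazol-2-yl gives an at least 1.6-fold lower number from compound 3 to compound 4 (0.22 log units; that floor lies within the scatter). Compound 3 has only a limit, so that step is a floor and its true size cannot be read: the limit of > 25000 nM in this assay, at which 3 of the 4 values shown sit.

The compounds shown leave open how a phenyl ring or an ethyl chain on this same nitrogen would read. They also leave open whether any such group would give a number clearly beyond the scatter.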